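The source may hold more compounds than are shown below. What is called first, only, known or untested is meant among the compounds shown, and "the series" means these compounds.

Working notes on the series in an ADME assay (liver) for metabolic stability, with Liver microsome (Rattus norvegicus) as the target, using microsomes and NADPH, with a stated time of 30 min; on this read-out higher numbers stand for fast clearance and lower numbers for slow clearance.

Three compounds carry numbers. Compound 1 `CC#C[C@H]1CN(S(=O)(=O)c2ccc(N)nc2)CCN1c1ncc(C(C)(O)C(F)(F)F)s1` gives 87 mL.min-1.g-1. Compound 2 `CC#C[C@H]1CN(S(=O)(=O)c2ccc(N)nc2)CCN1c1ccc(C(O)(COC)C(F)(F)F)cc1` gives 93 mL.min-1.g-1. Compound 3 `CC#C[C@H]1CN(S(=O)(=O)c2ccc(N)nc2)CCN1c1ncc(C(O)(C(F)(F)F)C(F)(F)F)s1` gives 34 mL.min-1.g-1. Compound 2 sits at the highest of the three numbers; compound 1 lies within the scatter of it, while compound 3 sits well apart from both. Within the data shown here, the one single-point step measured so far is a 2.6-fold lower number from compound 1 to compound 3 (0.41 log units; beyond the scatter).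

Compound 4 `CC#C[C@H]1CN(S(=O)(=O)c2ccc(N)nc2)CCN1c1ccc([S+](C)[O-])cc1` has not been measured. It differs from compound 2 in this way: a group of 3 heavy atoms (1 carbon, 1 oxygen, 1 sulfur; no ring) in place of a group of 9 heavy atoms (4 carbon, 2 oxygen, 3 fluorine; no ring), on an aromatic carbon, placed on an aromatic carbon of a six-membered aromatic ring of carbon only, para to a large group. Among the measured compounds shown here, no measured step touches this change directly: the step from compound 1 to compound 3 alters a substituent on the same kind of carbinol carbon and gives only a loose pointer, a modest lowering. On that basis a modest downward step is expected for compound 4 rather than none, with wide uncertainty, in this assay a step of a 1.6-fold lower number from compound 2 to compound 4 (0.19 log units; within the scatter). The expected value for compound 4 is 60 mL.min-1.g-1, with a range of 25 mL.min-1.g-1 to 150 mL.min-1.g-1.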

Compound 4, intrinsic clearance in microsomes: 17 mL.min-1.g-1
Compound 4: middle estimate off by 3.5-fold (0.55 log units), on the high side; the measured number lies below the stated range.
By their numbers in this assay, from the lowest: compounds 4 and 3 (each within the scatter of the next); then compounds 1 and 2 (each within the scatter of the next).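

In this assay, the substituent on an aromatic carbon of a six-membered aromatic ring of carbon only, para to a large group, clearly matters: the group of 3 heavy atoms (1 carbon, 1 oxygen, 1 sulfur; no ring) in place of the group of 9 heavy atoms (4 carbon, 2 oxygen, 3 fluorine; no ring) gives a 5.5-fold lower number from compound 2 to compound 4 (0.74 log units; beyond the scatter). The earlier step changed only one substituent on the carbinol carbon, whereas this one removes the whole carbinol group and shows that a low number at this position does not require trifluoromethyl or hydroxyl there. No measurement available here accounts for the size of this step. The pair cannot separate the departure of the larger group from the arrival of the smaller one. As far as these compounds go, how an amine or a nitrile would read at this position remains open.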